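A few compounds are considered here, and "the series" means these few. Any claim that something is new, unique, unknown or untested is made for them only; others in the source may bear on it.

Values in an ADME assay on THP-1 cells (Homo sapiens) for cytotoxicity, read by flow cytometry and propidium iodide staining, with a stated time of 72 h; a higher number here means a weaker inhibitor, a lower number a stronger inhibitor:
- compound 1 `Cn1cnc(CS(=O)(=O)c2ccc(F)cc2)c1[N+](=O)[O-]`: > 835000 nM (a limit)
- compound 2 `Cc1ccc(S(=O)(=O)Cc2nc(C)n(C)c2[N+](=O)[O-])cc1`: 242000 nM
- compound 3 `Cc1nc(CS(=O)(=O)c2ccc(Cl)cc2)c([N+](=O)[O-])n1C`: 68000 nM

Among the two actual numbers in this assay, compound 3 holds the lower one, 68000 nM. Its nearest neighbour is compound 2, and the gap is a 3.6-fold lower number from compound 2 to compound 3 (0.55 log units; beyond the scatter). The value of compound 1 is not a number but (the limit of > 835000 nM in this assay, at which 1 of the 3 values shown sits).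

The next compound is compound 4 `Cc1nc(CS(=O)(=O)c2ccc(F)cc2)c([N+](=O)[O-])n1C`, which differs from compound 3 by fluoro in place of chloro on an aromatic carbon. The same difference reads as 4-chlorophenyl to 4-fluorophenyl.

Two observations bear on this change. Among the measured compounds shown here, the only measured step at this aromatic carbon is a 3.6-fold lower number from compound 2 to compound 3 (0.55 log units; beyond the scatter), a modest step that puts chloro on the low side of methyl. Compound 1 also carries 4-fluorophenyl, and its reading is a limit, which points to the high side, although its core is not that of compound 3. For the measured compounds named here, no measured step leads directly from chloro to fluoro, so the size remains uncertain. In this assay, a step of similar modest size towards a higher number is expected, which would place compound 4 near compound 2.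

The expected change is a 2.6-fold higher number from compound 3 to compound 4 (0.42 log units; beyond the scatter). The estimate for compound 4 is 180000 nM, with an expected range of 70000 nM to 500000 nM.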

Compound 4, half-maximal inhibitory concentration: > 797000 nM
Compound 4: only a limit was reported; the forecaster's own chance of this, stated with the estimate: 15%; middle value at least 4.4-fold (0.64 log units) from the limit.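

In this assay, among the compounds shown here, the group on this aromatic carbon carries more weight than the earlier compounds showed: fluoro in place of chloro gives a large step (an at least 11-fold higher number from compound 3 to compound 4 (1.06 log units; beyond the scatter)), well beyond the modest step from methyl to chloro (a 3.6-fold lower number from compound 2 to compound 3 (0.55 log units; beyond the scatter)). Fluoro in place of methyl also raises the number (an at least 3.2-fold higher number from compound 2 to compound 4 (0.51 log units; beyond the scatter)), so on the shared core chloro sits lowest, methyl in the middle and fluoro highest, and the low number of compound 3 goes with chloro alone among these three groups. Compound 4 reads as a limit, and the step from compound 1, itself a limit, to compound 4 cannot be read: the limit of > 797000 nM in this assay, at which 1 of the 4 values shown sits.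

Only chloro, methyl and fluoro are shown on this carbon, so the place of bromo, methoxy, an amine or a carboxylic acid in this order stays open. As far as these compounds go, the true size of the step to compound 4 also stays open, as does whether chloro would keep its low number on the core of compound 1.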